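Moving a fluorine around the phenyl ring of compound 1

The source may hold more compounds than are shown below. What is called first, only, known or untested is meant among the compounds shown, and "the series" means these compounds.

Compound 1 `COc1cc(OC)cc(N2CCN(C(=O)c3oc(C)nc3-c3cccc(F)c3)CC2)c1`: 11.3%
Compound 2 `Cc1nc(-c2ccccc2)c(C(=O)N2CCN(c3cccc(C#N)c3)CC2)o1`: 8%
Compound 3 `Cc1nc(-c2ccccc2)c(C(=O)N2CCN(c3cccc(C)c3C)CC2)o1`: 29.8%

In an ADME assay (liver) for metabolic stability, with Liver microsome (Homo sapiens) as the target, read by LC-MS, using microsomes, with a stated time of 1 h, tested at 5 uM (on this read-out lower numbers stand for a less stable compound and higher numbers for a more stable compound), compound 1 gives 11.3%, the second highest of the three numbers; compound 2 sits within the scatter of it, while compound 3 lies beyond the scatter above it. Compound 4 `COc1cc(OC)cc(N2CCN(C(=O)c3oc(C)nc3-c3ccccc3F)CC2)c1` differs from compound 1 only in the change (2-fluorophenyl in place of 3-fluorophenyl on an aromatic carbon). Among the measured compounds shown here, the single measured step, a number 21.8 percentage points higher from compound 2 to compound 3 (beyond the scatter), concerns a different place of the shared core, the group on an amine nitrogen in a ring, so no measured step speaks to a fluorine moved on the aromatic carbon. With no guide, compound 4 is expected to change by a number 0.7 percentage points higher from compound 1 to compound 4 (within the scatter), a step within the scatter. Compound 4 is therefore estimated at 12%, with a range from 4% to 26%.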

Compound 4, percent of the compound remaining: 15%
Compound 4: the middle estimate sits 3 percentage points below what was measured; the measured number falls inside the stated range.
By their numbers in this assay, from the lowest: compounds 2, 1 and 4 (each within the scatter of the next); then compound 3.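

Moving the fluorine on this aromatic carbon of the shared core, with 2-fluorophenyl in place of 3-fluorophenyl, gives in this assay a number 3.7 percentage points higher from compound 1 to compound 4 (within the scatter). Among the compounds shown here, this is the first measured step at this position, and on this read-out the two fluorine placements cannot be told apart. Nothing measured here bears on the reason for this result.

As far as these compounds go, whether a larger step is possible at this position remains open. An amine or a carboxylic acid in place of the fluorine could show whether this phenyl ring affects the read-out more strongly.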